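The source may report more compounds than this note shows. Statements on the series, on what has been measured and on what is new or still open speak of the compounds shown alone.

Three compounds were measured in a functional assay on NCI-H226 cells (Homo sapiens) for inhibition, read by MTT assay, with a stated time of 48 h, tested at 10 uM; on this read-out higher numbers stand for more inhibition at the one concentration tested (going by the name of the read-out) and lower numbers for less inhibition:
Compound 1 `COc1ccc(Br)cc1Nc1cc(NC(=O)Nc2c(Cl)cccc2Cl)ncn1`: 33%
Compound 2 `COc1cc(NC(=O)Nc2cc(Nc3ccc(OC)c(I)c3)ncn2)cc(OC)c1`: 40.1%
Compound 3 `COc1cc(NC(=O)Nc2cc(Nc3cc(C(F)(F)F)ccc3OC)ncn2)cc(OC)c1`: 60%

Among these three, compound 2 stands second highest in this assay. Its nearest neighbour is compound 1, whose value lies within the scatter of that of compound 2, so the two cannot be ordered. Compound 3 lies furthest away, with a value beyond the scatter above that of compound 2.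

Compound 4 `COc1cc(NC(=O)Nc2cc(Nc3ccc(C(C)(C)C)cc3)ncn2)cc(OC)c1` has not yet been measured. It differs from compound 2 in one place: 4-(tert-butyl)phenyl in place of 3-iodo-4-methoxyphenyl on a nitrogen on an aromatic ring. Among the measured compounds shown here, no step between measured compounds matches this change, so no measured guide exists. Compound 4 is expected to show a step of a number 1.9 percentage points higher from compound 2 to compound 4 (within the scatter) in this assay, which would fall within the scatter. The expected value for compound 4 is 42%, with a range from 20% to 65%.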

Compound 4, a percentage reported as inhibition, at one concentration (the size of the read-out at that concentration, not a potency): 47.7%
For compound 4 the middle estimate is 5.7 percentage points below the measured one, within the range that was stated.
By their numbers in this assay, from the lowest: compounds 1, 2 and 4 (each within the scatter of the next, the first and the last beyond it); then compound 3.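

In this assay, 4-(tert-butyl)phenyl in place of 3-iodo-4-methoxyphenyl gives a number 7.6 percentage points higher from compound 2 to compound 4 (within the scatter), so the two compounds cannot be ordered. This first one-place comparison at this nitrogen shows that a group of carbon only, with no hydrogen-bond acceptor, reads alike with one carrying iodine and oxygen. Nothing at hand explains this result. Still open, going by these compounds, is how a phenyl ring carrying an amine or a carboxylic acid would read at this position. On these data alone, whether the same holds with other groups on the far side of the urea also remains open.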